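The source may report more compounds than this note shows. Statements on the series, on what has been measured and on what is new or still open speak of the compounds shown alone.

Compound 1 `CCN(Cc1cccs1)C(=O)COc1ccc(C)cc1` is a small amide in which an ethyl group and a thiophen-2-ylmethyl group sit on the amide nitrogen. In an assay on HEK293 cells for agonist activity at transient receptor potential cation channel subfamily M member 8 (Homo sapiens), read by fluorescence and calcium flux, with a stated time of 15 min (on this read-out higher numbers stand for an effect only at larger amounts of compound and lower numbers for an effect already at smaller amounts), compound 1 gives 8 nM, the lowest of the two numbers in this set. Compound 3 `CCN(Cc1cc[nH]c1)C(=O)COc1ccc(C)cc1` gives 21800 nM, and the change a 2700-fold higher number from compound 1 to compound 3 (3.44 log units; beyond the scatter). Compound 2 `CCN(C(=O)COc1ccc(C)cc1)C(C)c1cccs1` is reported as "not active" (no number reported). Compound 4 `Cc1ccc(OCC(=O)N(Cc2cccs2)C(C)(C)C)cc1` differs from compound 1 at another place: tert-butyl in place of ethyl on an amide-type nitrogen. Within the data shown here, no measured step changes this position, so there is no direct guide. The large move for compound 3 and the loss seen with compound 2 suggest a sensitive series, so a moderate weakening is expected, a 5.0-fold higher number from compound 1 to compound 4 (0.70 log units; beyond the scatter). Compound 4 is estimated at 40 nM, between 6 nM and 300 nM.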

Compound 4, half-maximal effective concentration: 11000 nM
Estimate against measurement, compound 4: 280-fold (2.44 log units) below; measured number above the stated range.
By their numbers in this assay, from the lowest: compound 1; then compounds 4 and 3 (each within the scatter of the next).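

In this assay, among these compounds, replacing ethyl with tert-butyl on the amide nitrogen gives a 1400-fold higher number from compound 1 to compound 4 (3.14 log units; beyond the scatter) and so shows that this position, which no earlier step had changed, is also highly sensitive. Activity at this receptor therefore depends on the ethyl group as well as on the thiophen-2-yl ring that compound 3 had changed. Nothing measured here explains why this swap has so large an effect. The compounds shown leave open how methyl, propyl or isopropyl would behave on this nitrogen. They also leave open whether the number climbs steadily as the group grows or jumps only with tert-butyl.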